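Isobutyl for hydrogen on the amide-bearing chain carbon

A few compounds are considered here, and "the series" means these few. Any claim that something is new, unique, unknown or untested is made for them only; others in the source may bear on it.

Compound 3 `O=C(CN(c1ncnc2c1ncn2C1CCCCO1)C1CC1)NCC(=O)OCc1ccccc1` gives 40.4% in a functional assay on the whole organism (Tail, strain ICR) with Mus musculus as the target, in the tail flick test, with a stated time of 60 min, at a dose of 25 umol/kg by the oral route (a lower number here means a weaker effect, a higher number a stronger effect of the compound at the dose given), the second highest of three numbers. Compound 2 `CC(C)[C@H](NC(=O)CN(c1ncnc2c1ncn2C1CCCCO1)C1CC1)C(=O)OCc1ccccc1` gives 34.9%, and a number 5.5 percentage points higher from compound 2 to compound 3 (within the scatter). Compound 1 `N=C(N)NCCC[C@H](NC(=O)CN(c1ncnc2c1ncn2C1CCCCO1)C1CC1)C(=O)OCc1ccccc1` gives 52.4%; a number 12 percentage points lower from compound 1 to compound 3 (beyond the scatter), and a number 17.5 percentage points lower from compound 1 to compound 2 (beyond the scatter). Compound 4 `CC(C)C[C@H](NC(=O)CN(c1ncnc2c1ncn2C1CCCCO1)C1CC1)C(=O)OCc1ccccc1` carries isobutyl in place of hydrogen on a saturated chain carbon bound to an amide-type nitrogen and a carbonyl carbon. The step that bears on it most is the one with isopropyl, where removing that branched group moved the number only within the scatter; read backwards, adding a branched alkyl group at this carbon is expected to change little. The larger steps that involve compound 1 concern a quite different group and speak less to an isobutyl. The expected step is therefore a number 3.4 percentage points lower from compound 3 to compound 4 (within the scatter), within the scatter. Compound 4 is estimated at 37%, with a range from 25% to 50%.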

Compound 4, a percentage reported as activity, at one dose (the size of the read-out at that dose, not a potency): 34.2%
Estimate against measurement, compound 4: 2.8 percentage points above; low and high end bracket the measured number.
By their numbers in this assay, from the lowest: compounds 4, 2 and 3 (each within the scatter of the next); then compound 1.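

Isobutyl on this saturated chain carbon behaves like isopropyl: neither separates from hydrogen (a number 6.2 percentage points lower from compound 3 to compound 4 (within the scatter)), and the two alkyl groups do not separate from each other (a number 0.7 percentage points lower from compound 2 to compound 4 (within the scatter)). The gap to the chain of compound 1 persists with a second alkyl group (a number 18.2 percentage points lower from compound 1 to compound 4 (beyond the scatter)), so that chain alone stands apart among these compounds. Nothing measured here accounts for these numbers. On these data alone, whether a simple amine or a carboxylic acid at the end of a chain on this carbon would match compound 1 stays open. So does whether a longer unbranched alkyl chain would differ from isobutyl.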